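This account rests on a few compounds, and the source may have more. Where it says the series, first, only, none or still open, it means among the compounds named here.

Measured so far in a functional assay on OVCAR-4 cells (Homo sapiens) for cytotoxicity, read by sulforhodamine B assay, with a stated time of 48 h, tested at 0.01 uM; on this read-out higher numbers stand for a weaker effect at the one concentration tested and lower numbers for a stronger effect:
compound 1 `Cc1cc(O)cc(-c2nn(CC#N)cc2-c2ccnc(-c3ccc(Oc4ccccc4)cc3)c2)c1`, giving 112%;
compound 2 `COc1cc(C)cc(-c2nn(CC#N)cc2-c2ccnc(-c3ccc(N(C)C)cc3)c2)c1`, giving 98%.

Compound 2 stands lowest of the two numbers; its nearest neighbour is compound 1, a number higher by a gap beyond the scatter. Compound 3 `Cc1cc(O)cc(-c2nn(CC#N)cc2-c2ccnc(-c3ccc(N(C)C)cc3)c2)c1` differs from compound 2 in one place: hydrogen in place of methyl on an oxygen on an aromatic ring. Among the compounds with values here, no step between measured compounds tells what this change does; the two values of compound 1 and compound 2 differ in two places at once. From compound 2 to compound 3 a step of a number 5 percentage points higher from compound 2 to compound 3 (within the scatter) is expected, small and within the scatter. Compound 3 is estimated at 103%, between 86% and 120%.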

Compound 3, a percentage reported as activity, at one concentration (the size of the read-out at that concentration, not a potency): 108%
The estimate for compound 3 lay 5 percentage points below the measured number; the measured number falls inside the stated range.
By their numbers in this assay, from the lowest: compounds 2, 3 and 1 (each within the scatter of the next, the first and the last beyond it).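

In this assay, methoxy to hydroxy on the 3-methoxy-5-methylphenyl group gives a number 10 percentage points higher from compound 2 to compound 3 (within the scatter), so the methyl on this oxygen can go without a step beyond the scatter. Dimethylamino in place of phenoxy on an aromatic carbon, now readable alone, gives a number 4 percentage points lower from compound 1 to compound 3 (within the scatter), so these two groups are not told apart at this concentration. Nothing measured here gives a cause for either step. Still open, as far as these compounds go, is whether a longer chain on this oxygen, such as ethoxy, would shift the read-out. Also open, from the compounds shown here alone, is whether an amine in place of dimethylamino would do so.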